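Trading oxetane for methyl on the pyrazole

This account rests on a few compounds, and the source may have more. Where it says the series, first, only, none or still open, it means among the compounds named here.

Compound 3 `Cc1c(Nc2nc(N)c3c(C#N)c(N4CCC[C@H]4C)n(C)c3n2)cnn1C1COC1` gives 190 nM in an assay on HEK293 cells for inhibition of Leucine-rich repeat serine/threonine-protein kinase 2 variant G2019S (Homo sapiens), with a stated time of 48 h; on this read-out lower numbers stand for stronger inhibition and higher numbers for weaker inhibition. That number sits within the usual scatter of compound 2 `Cc1nn(CC(C)(C)O)cc1Nc1nc(N)c2c(C#N)c(N3CCC[C@H]3C)n(C)c2n1` at 180 nM and compound 1 `Cc1nn(C2COC2)cc1Nc1nc(N)c2c(C#N)c(N3CCC[C@H]3C)n(C)c2n1` at 140 nM, the step of a 1.4-fold higher number from compound 1 to compound 3 (0.13 log units; within the scatter) being too small to rank them. The unmeasured compound 4 `Cc1nn(C)cc1Nc1nc(N)c2c(C#N)c(N3CCC[C@H]3C)n(C)c2n1` carries 1,3-dimethyl-1H-pyrazol-4-yl in place of 5-methyl-1-(oxetan-3-yl)-1H-pyrazol-4-yl on a nitrogen on an aromatic ring. Within the data shown here, two measured steps bear on it: the swap of the methyl position, a 1.4-fold higher number from compound 1 to compound 3 (0.13 log units; within the scatter), and the change of the group on the pyrazole nitrogen, a 1.3-fold higher number from compound 1 to compound 2 (0.11 log units; within the scatter), both within the scatter. Nothing here suggests that a methyl at that nitrogen should behave differently, so no step beyond the scatter is expected for compound 4, with a 1.2-fold lower number from compound 3 to compound 4 (0.07 log units; within the scatter) as the estimated change. Compound 4 is therefore estimated at 160 nM, in the range 70 nM to 360 nM.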

Compound 4, half-maximal inhibitory concentration: 120 nM
Beside the measured number, compound 4's estimate is 1.3-fold (0.12 log units) above it; the measured number falls inside the stated range.
By their numbers in this assay, from the lowest: compounds 4, 1, 2 and 3 (each within the scatter of the next).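

With methyl on the aromatic nitrogen, this assay shows no step beyond the scatter from either larger group: a 1.2-fold lower number from compound 1 to compound 4 (0.07 log units; within the scatter) for the loss of oxetan-3-yl and a 1.5-fold lower number from compound 2 to compound 4 (0.18 log units; within the scatter) for the loss of 1-hydroxy-1-methylethyl from the 2-hydroxy-2-methylpropyl chain. The full exchange of 5-methyl-1-(oxetan-3-yl)-1H-pyrazol-4-yl for 1,3-dimethyl-1H-pyrazol-4-yl, a 1.6-fold lower number from compound 3 to compound 4 (0.20 log units; within the scatter) and also within the scatter, shows that this place tolerates losing the four-membered ring. No measurement given here explains this flatness. Going by these compounds, whether that tolerance extends to a piperidin-4-yl amine or a carboxylic acid chain on that nitrogen remains open.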